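Iodo for fluoro at the ortho position

A few compounds are considered here, and "the series" means these few. Any claim that something is new, unique, unknown or untested is made for them only; others in the source may bear on it.

Of the compounds shown here, two of a shared core have been measured in an assay for inhibition of Dihydrofolate reductase (Gallus gallus); a lower number here means a stronger inhibitor, a higher number a weaker inhibitor. Compound 1 `C=CCOc1ccccc1Cc1cnc(N)nc1N` gives 21400 nM, and compound 2 `Nc1ncc(Cc2ccccc2F)c(N)n1` gives 43700 nM. Compound 2 holds the highest of the two numbers, its nearest neighbour being compound 1, separated by a 2.0-fold higher number from compound 1 to compound 2 (0.31 log units; beyond the scatter), a change of fluoro in place of allyloxy on an aromatic carbon. Compound 3 `Nc1ncc(Cc2ccccc2I)c(N)n1` differs from compound 2 by iodo in place of fluoro on an aromatic carbon. For the measured compounds named here, no measured step involves an iodo group, so the one known step, which exchanges fluoro for allyloxy, bears on it only loosely: both iodo and allyloxy are substituents heavier than fluorine at this place, and fluorine gave the weaker result there. A modest gain is therefore expected for compound 3, with a 2.2-fold lower number from compound 2 to compound 3 (0.34 log units; beyond the scatter). Compound 3 is estimated to give 20000 nM in this assay, within a range of 6000 nM to 60000 nM.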

Compound 3, inhibition constant: 8710 nM
The estimate for compound 3 lay 2.3-fold (0.36 log units) above the measured number; the range from low to high includes it.
By their numbers in this assay, from the lowest: compound 3; then compound 1; then compound 2.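

In this assay, for the compounds shown here, the earlier compounds showed only that fluoro gave a higher number than allyloxy at this aromatic carbon, and the new result shows that the group here can also move the number the other way. Iodo in place of fluoro gives a clear drop (a 5.0-fold lower number from compound 2 to compound 3 (0.70 log units; beyond the scatter)), and iodo in place of allyloxy also gives a lower number (a 2.5-fold lower number from compound 1 to compound 3 (0.39 log units; beyond the scatter)), so for these three groups alone the order from the lowest number is iodo, allyloxy, fluoro. No measurement in hand explains this order.

As far as these compounds go, whether chloro or bromo would fall between fluoro and iodo remains open, as does whether methoxy or a longer ether chain would sit near allyloxy. The compounds also leave open how plain hydrogen at this carbon would compare with all three groups.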